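The source may hold more compounds than are shown below. What is called first, only, known or untested is meant among the compounds shown, and "the series" means these compounds.

Measured compounds:
compound 1 `COc1cnc(-c2ccccn2)nc1N(C)C1CCCC1`: > 1000 mL/min/kg
compound 2 `COc1cnc(-c2ccccn2)nc1NCc1ccccc1C`: 791 mL/min/kg

In an in vitro ADME assay on microsomes from liver (Rattus norvegicus) for metabolic stability, read by LC-MS, tested at 0.05 uM (a higher number here means faster removal of the compound, a lower number slower removal), compound 1 gives > 1000 mL/min/kg, which is a limit of the assay and not a number. In this assay compound 2 gives 791 mL/min/kg. Where compound 1 stands among these two can therefore be stated only in part: the limit of > 1000 mL/min/kg in this assay, at which 1 of the 2 values shown sits. Within the data shown here, no step between measured compounds that differ in one place is available, so nothing measured tells how large a single structural alteration moves the clearance in this assay.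

Compound 3 `COc1cnc(-c2ccccn2)nc1C1CCCC1` differs from compound 1 in one place: cyclopentyl in place of cyclopentyl(methyl)amino on an aromatic carbon. In words, cyclopentyl takes the place of cyclopentyl(methyl)amino on an aromatic carbon. Among the measured compounds shown here, no measured pair shows the effect of this particular change, and only a limit is known for compound 1, so the starting point of the step is itself uncertain. The step expected for compound 3, an at least 1.8-fold lower number from compound 1 to compound 3 (0.25 log units; that floor lies within the scatter), is toward slower removal, and larger than the usual scatter. Compound 3 is expected to give 550 mL/min/kg in this assay, with a range from 220 mL/min/kg to 1400 mL/min/kg.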

Compound 3, clearance: > 1000 mL/min/kg
Compound 3 ended at the assay's limit; the forecaster's own chance of this, stated with the estimate: 25%; middle value at least 1.8-fold (0.25 log units) from the limit.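

In this assay compound 3 gives > 1000 mL/min/kg as a limit of the assay and not a number. Among these compounds, compound 1 also stands at a limit, so no step between compound 1 and compound 3 can be read. The compounds shown leave open whether cyclopentyl in place of cyclopentyl(methyl)amino on an aromatic carbon changes the clearance at all.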